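A few compounds are considered here, and "the series" means these few. Any claim that something is new, unique, unknown or untested is made for them only; others in the source may bear on it.

Compound 1, `O=C(/C=C/c1ccncc1)c1cccc(C(F)(F)F)c1`, gives 41000 nM in a functional assay with Rattus norvegicus as the target; on this read-out higher numbers stand for weaker inhibition and lower numbers for stronger inhibition. Compound 2, `Cc1cccc(C(=O)/C=C/c2ccncc2)c1`, gives 39000 nM in this assay.

For the measured compounds named here, compound 2 has the lower of the two numbers, but the only step, a 1.1-fold lower number from compound 1 to compound 2 (0.02 log units; within the scatter), lies within the scatter, so the two compounds cannot be told apart. Compound 3, `O=C(/C=C/c1ccncc1)c1cccc(Cl)c1`, is the next compound: chloro in place of methyl on an aromatic carbon. Going by the values given here, no measured step exchanges methyl for chloro, and the one step that exists at this carbon, a 1.1-fold lower number from compound 1 to compound 2 (0.02 log units; within the scatter), showed no movement beyond the scatter. Compound 3 is therefore expected to stay near compound 2, a 1.0-fold higher number from compound 2 to compound 3 (0.01 log units; within the scatter). The estimate for compound 3 in this assay is 40000 nM, within 15000 nM to 100000 nM.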

Compound 3, half-maximal inhibitory concentration: 69000 nM
For compound 3 the middle estimate is 1.7-fold (0.24 log units) below the measured one; the range from low to high includes it.
By their numbers in this assay, from the lowest: compounds 2, 1 and 3 (each within the scatter of the next).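

With chloro, this aromatic carbon has now carried three different groups in this assay, and the number still does not move beyond the scatter: the new steps are a 1.8-fold higher number from compound 2 to compound 3 (0.25 log units; within the scatter) and a 1.7-fold higher number from compound 1 to compound 3 (0.23 log units; within the scatter). Methyl, trifluoromethyl and chloro therefore cannot be told apart here, a reading that now rests on three groups instead of one exchange. (No measured property of these compounds bears on this result).

The compounds shown leave open whether an amine or a carboxylic acid on this carbon would shift the number beyond the scatter. They also leave open whether any change elsewhere on the shared core would do so.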